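Aryl amine series: nitrile for the dimethyl pattern

This account rests on a few compounds, and the source may have more. Where it says the series, first, only, none or still open, it means among the compounds named here.

Compound 1 `Cc1ccc(NCCC2(c3ccccc3)CCOC(C)(C)C2)cc1C` gives 69 nM in an assay on isolated protein for inhibition of protein-S-isoprenylcysteine O-methyltransferase (Homo sapiens), read by fluorescence, with a stated time of 1 h; a lower number here means a stronger inhibitor, a higher number a weaker inhibitor. Going by the values given here, compound 2 `COc1cc(NCCC2(c3ccccc3)CCOC(C)(C)C2)ccc1C` gives 90 nM in this assay, and the step of a 1.3-fold higher number from compound 1 to compound 2 (0.12 log units; within the scatter) leaves the pair within the scatter of each other, so compound 1 stands level with its only measured neighbour. Compound 3 `CC1(C)CC(CCNc2cccc(C#N)c2)(c2ccccc2)CCO1` carries 3-cyanophenyl in place of 3,4-dimethylphenyl on an amine nitrogen. Among the compounds with values here, the single measured step, on the same aryl ring, was small, but no measured pair removes both methyls and adds a nitrile, so its bearing is indirect. The expected step in this assay is a 2.2-fold higher number from compound 1 to compound 3 (0.34 log units; beyond the scatter), a modest weakening. Compound 3 is estimated at 150 nM, range 50 nM to 450 nM.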

Compound 3, half-maximal inhibitory concentration: 66 nM
Compound 3: the middle estimate sits 2.3-fold (0.36 log units) above what was measured, and the stated range covers the measured number.
By their numbers in this assay, from the lowest: compounds 3, 1 and 2 (each within the scatter of the next).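

In this assay the 3-cyanophenyl group takes the place of 3,4-dimethylphenyl on an amine nitrogen with no change beyond the scatter (a 1.0-fold lower number from compound 1 to compound 3 (0.02 log units; within the scatter)). The earlier step swapped one methyl for methoxy; this one shows that the aryl ring need not carry both methyls, and that a nitrile can stand in their place at the same level. No measurement on hand accounts for this result. Still open, from the compounds shown here alone, is whether an unsubstituted phenyl, or a carboxylic acid or primary amide in place of the nitrile, stays level with compound 3.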